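A few compounds are considered here, and "the series" means these few. Any claim that something is new, unique, unknown or untested is made for them only; others in the source may bear on it.

Compound 3 `NC(=O)Cn1c(=O)n(C2OC(CO)[C@@H](O)[C@H]2O)c2nc(N)nc(O)c21` stands second highest of the three values in a functional assay on the whole organism (B cells) with Mus musculus as the target; a lower number here means a smaller maximal response, a higher number a larger maximal response: compound 3 gives 32%, while compound 2 `Nc1nc(O)c2c(n1)n(C1OC(CO)[C@@H](O)[C@H]1O)c(=O)n2Cc1ccc(Cl)cc1` gives 15% and compound 1 `[N-]=[N+]=NCC(O)Cn1c(=O)n(C2OC(CO)[C@@H](O)[C@H]2O)c2nc(N)nc(O)c21` gives 91%. The step of a number 17 percentage points higher from compound 2 to compound 3 (beyond the scatter) is modest, whereas the step of a number 59 percentage points lower from compound 1 to compound 3 (beyond the scatter) is large, and compound 1 also stands far from compound 2, as a number 76 percentage points lower from compound 1 to compound 2 (beyond the scatter) shows. Compound 4 `Nc1nc(O)c2c(n1)n(C1OC(CO)[C@@H](O)[C@H]1O)c(=O)n2Cc1ccccc1` differs from compound 3 by phenyl in place of carbamoyl on a saturated chain carbon bound to an aromatic nitrogen. This is nearly the reverse of the step from compound 2 to compound 3, except that the ring entering compound 4 is a plain phenyl rather than the 4-chlorophenyl of compound 2. For the measured compounds named here, the one step that bears on it is therefore a number 17 percentage points higher from compound 2 to compound 3 (beyond the scatter), modest and pointing the other way, and the absence of the chlorine leaves the match incomplete. Compound 4 is expected to show a modest drop, a number 14 percentage points lower from compound 3 to compound 4 (beyond the scatter), on the return of an aromatic ring at that place. The estimate for compound 4 is 18%, with a range from 8% to 35%.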

Compound 4, largest response reached (reported as maximal response), in percent of the reference or control that the assay uses: 110%
The estimate for compound 4 lay 92 percentage points below the measured number, and the stated range ends below it.
By their numbers in this assay, from the lowest: compound 2; then compound 3; then compound 1; then compound 4.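

In this assay, an aromatic ring on the saturated chain carbon bound to an aromatic nitrogen does not by itself hold the response low: phenyl in place of carbamoyl gives a number 78 percentage points higher from compound 3 to compound 4 (beyond the scatter), and hydrogen in place of chloro on an aromatic carbon gives a number 95 percentage points higher from compound 2 to compound 4 (beyond the scatter), so the low number of the chlorinated benzyl compound belongs to the chloro and not to the ring. Phenyl also outdoes 2-azido-1-hydroxyethyl at this place, with a number 19 percentage points higher from compound 1 to compound 4 (beyond the scatter), which leaves compound 4 with the highest number of the four, its steps to all others beyond the scatter. Nothing shown offers a reason for the size of these steps.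

The compounds shown leave open whether fluoro, methoxy or an amine on the phenyl ring would lower the number as chloro does. They also leave open whether a longer chain such as 2-phenylethyl in place of benzyl would keep it high.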